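From methyl to ethyl on the amide-type nitrogen

The source may report more compounds than this note shows. Statements on the series, on what has been measured and on what is new or still open speak of the compounds shown alone.

In a functional assay on the whole organism with Mus musculus as the target (on this read-out higher numbers stand for an effect only at larger amounts of compound and lower numbers for an effect already at smaller amounts), compound 1 `O=C1CCC(O)(c2cccc(C(F)(F)F)c2)N1` gives > 200 mg/kg, which is a limit of the assay and not a number. Among the compounds with values here, compound 2 `CN1C(=O)CCC1(O)c1cccc(C(F)(F)F)c1` gives 133 mg/kg, so it holds the only true number so far, with nothing firm to rank it against.

The next compound, compound 3 `CCN1C(=O)CCC1(O)c1cccc(C(F)(F)F)c1`, carries one change: methyl in place of hydrogen on a saturated chain carbon bound to an amide-type nitrogen in a ring. This is methyl in place of hydrogen on a saturated chain carbon bound to an amide-type nitrogen in a ring, which turns methyl into ethyl.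

Within the data shown here, only one measured step can serve as a guide, and it is a related change at the same nitrogen rather than the same one: an at least 1.5-fold lower number from compound 1 to compound 2 (0.17 log units; that floor lies within the scatter). That step was methyl in place of hydrogen on the nitrogen itself. From the compounds shown here alone, its true size is unknown, since one end of it is a limit, so it gives no firm direction for the added carbon.

No shift beyond the scatter is therefore expected in this assay. The estimated change is a 1.2-fold lower number from compound 2 to compound 3 (0.06 log units; within the scatter). For compound 3 the expected value is 115 mg/kg, within an estimated range of 55 mg/kg to 230 mg/kg.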

Compound 3, dose for half-maximal effect: > 100 mg/kg
Compound 3: no number, only a limit; the forecaster's own chance of this, stated with the estimate: 15%; the middle value does not contradict the limit.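

In this assay compound 3 gives > 100 mg/kg, which is a limit of the assay and not a number. The steps from compound 2 to compound 3 and from compound 1 to compound 3 therefore cannot be read. The compounds shown leave open whether ethyl on the amide-type nitrogen gives a lower or a higher number than methyl there.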